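Heteroaryl amide change from compound 2 to compound 3

A few compounds are considered here, and "the series" means these few. Any claim that something is new, unique, unknown or untested is made for them only; others in the source may bear on it.

Compound 1 `O=C(COc1ccc(/C=C2\SC(=O)NC2=O)cc1)Nc1ncc([N+](=O)[O-])s1` carries 5-nitro-1,3-thiazol-2-yl on the amide-type nitrogen; compound 2 `O=C(COc1ccc(/C=C2\SC(=O)NC2=O)cc1)Nc1ccccn1` carries pyridin-2-yl in the same place. In a functional assay on K562 cells (Homo sapiens) for cytotoxicity, read by sulforhodamine B assay, with a stated time of 48 h (on this read-out higher numbers stand for weaker inhibition of growth and lower numbers for stronger inhibition of growth), compound 1 gives < 100000 nM, which is a limit of the assay and not a number. In this assay compound 2 gives < 100000 nM, likewise a limit only. The step that the two limits leave unreadable from compound 1 to compound 2 cannot be read, because both values sit at the limit of < 100000 nM in this assay, at which 2 of the 2 values shown sit. Compound 2 therefore stands at a limit only, with no number that would place it against compound 1.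

Compound 3 `Cc1cc(NC(=O)COc2ccc(/C=C3\SC(=O)NC3=O)cc2)no1` differs from compound 2 by 5-methyl-1,2-oxazol-3-yl in place of pyridin-2-yl on an amide-type nitrogen. Going by the values given here, the single measured step also exchanges the heteroaryl group on the amide-type nitrogen, and its size is not readable from the two limits; so the measured data give neither a direction nor a size for the change from compound 2 to compound 3 in this assay.

The step that the limit leaves unreadable from compound 2 to compound 3 is accordingly expected to stay within the scatter, with no direction claimed. For compound 3 the estimate in this assay is 30000 nM, with a range from 3000 nM to 100000 nM, and a result reported only as a limit is expected to be the most likely outcome.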

Compound 3, concentration for total growth inhibition: < 100000 nM
Compound 3: no number, only a limit; the forecaster's own chance of this, stated with the estimate: 70%; the middle value lies beyond the limit too.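

In this assay compound 3 gives < 100000 nM, a limit and not a number. No step among compound 1, compound 2 and compound 3 can be read, because all of them stand at the same limit: the limit of < 100000 nM in this assay, at which 3 of the 3 values shown sit.

The compounds shown leave open whether the heteroaryl groups on the amide-type nitrogen differ at all in this read-out.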